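Metabolic stability notes: fluorine pattern on the pendant phenyl

This account rests on a few compounds, and the source may have more. Where it says the series, first, only, none or still open, it means among the compounds named here.

Going by the values given here, compound 2 `O=C(Nc1ccc(F)c(-c2nc3ncc(-c4ccccc4F)cc3[nH]2)c1)N1CCCC1` is the only member of the set with a number in an ADME assay on microsomes from liver (Homo sapiens) for metabolic stability, read by LC-MS; a lower number here means that the compound disappears faster, a higher number that the compound lasts longer: there compound 2 gives 0.285 h. The two other values shown are limits of the assay. Compound 1 `Cc1nc(C)c(C(=O)Nc2ccc(F)c(-c3nc4ncc(-c5cccnc5Cl)cn4n3)c2)o1` in this assay gives > 1.5 h, which is a limit and not a number. Compound 3 `Cc1nc(C)c(C(=O)Nc2ccc(F)c(-c3nc4ncc(-c5ccccc5Cl)cn4n3)c2)o1` in this assay gives > 1.5 h, again a limit. Among the compounds with values here, the one step between measured compounds, a step that the two limits leave unreadable from compound 1 to compound 3, is therefore unreadable in size, and it sits on a core that compound 2 does not share.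

The move to compound 4 `O=C(Nc1ccc(F)c(-c2nc3ncc(-c4ccc(F)c(F)c4)cc3[nH]2)c1)N1CCCC1` is 3,4-difluorophenyl in place of 2-fluorophenyl on an aromatic carbon. Within the data shown here, no measured step in this assay bears on a change of this kind, and the pair compound 1 to compound 3 tells nothing of size because the limit of > 1.5 h in this assay, at which 2 of the 3 values shown sit, holds both of its values. The expectation for compound 4 is therefore set by compound 2 alone: a step of a 1.2-fold higher number from compound 2 to compound 4 (0.09 log units; within the scatter) that is expected to stay within the scatter. Compound 4 is estimated at 0.35 h in this assay, with a range from 0.15 h to 0.9 h.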

Compound 4, half-life: 0.282 h
For compound 4 the middle estimate is 1.2-fold (0.09 log units) above the measured one; measured number inside the range.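

In this assay, going by these compounds alone, the one readable step at this position, on an aromatic carbon of a six-membered aromatic ring with 1 nitrogen, is a 1.0-fold lower number from compound 2 to compound 4 (0.00 log units; within the scatter). On the core of compound 2, the half-life therefore does not separate 2-fluorophenyl from 3,4-difluorophenyl, a finding that rests on this single pair and extends to no other substituent or core. Nothing among the data shown gives a reason for this outcome.

Within the data shown here, the only other step, between compound 1 and compound 3, cannot be read, since both of its values are limits of the assay, and it lies on a different core, so it gives no information on whether the fluorine change would behave the same way there. As far as these compounds go, it also remains open whether a group of a different kind at this position, such as a morpholine, an amine or a carboxylic acid in place of the fluorinated phenyl, would give a half-life beyond the scatter of the value for compound 2.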